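Quinolinone series: chain extension at the ring nitrogen

This account rests on a few compounds, and the source may have more. Where it says the series, first, only, none or still open, it means among the compounds named here.

Measured so far in a functional assay on T47D cells (Homo sapiens) for cytotoxicity, read by colorimetric assay and MTT assay; a lower number here means a stronger inhibitor, a higher number a weaker inhibitor:
Compound 1 `CCOC(=O)Cn1c(=O)c(-c2ccc(OC)cc2)cc2c(OC)cc(OC)cc21`: 10000 nM
Compound 2 `CCN(CC)C(=O)Cn1c(=O)c(-c2ccc(OC)cc2)cc2c(OC)cc(OC)cc21`: 10000 nM
Compound 3 `COc1ccc(-c2cc3c(OC)cc(OC)cc3n(CC(=O)O)c2=O)cc1`: 10000 nM

Compound 3 stands level with compounds 1 and 2 in this assay; the steps of no change at the digits printed from compound 1 to compound 3 (within the scatter) and no change at the digits printed from compound 2 to compound 3 (within the scatter) both lie within the scatter, as does no change at the digits printed from compound 1 to compound 2 (within the scatter). Nothing in this set has yet moved the read-out, whichever group sits on the carbonyl carbon of the chain.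

Compound 4 `CCN(CC)C(=O)CCn1c(=O)c(-c2ccc(OC)cc2)cc2c(OC)cc(OC)cc21` is next. The change from compound 3 is (diethylcarbamoyl)methyl in place of carboxy on a saturated chain carbon bound to an aromatic nitrogen. Compound 2 already carries the diethylcarbamoyl group on a shorter chain, and the step of no change at the digits printed from compound 2 to compound 3 (within the scatter), which swaps that group for hydroxy, showed nothing beyond the scatter. For the measured compounds named here, the further chain carbon in compound 4 has no measured counterpart here, so no step size can be read off for it. On this basis compound 4 is expected to show no movement beyond the scatter, estimated as no change at the digits printed from compound 3 to compound 4 (within the scatter), giving an expected value of 10000 nM with a range of 5000 nM to 20000 nM.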

Compound 4, half-maximal inhibitory concentration: 10000 nM
For compound 4 middle estimate and measured number coincide at the digits printed; the range from low to high includes it.
By their numbers in this assay, from the lowest: compounds 1, 2, 3 and 4 (each within the scatter of the next).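

The earlier compounds shown here varied only the group on the carbonyl carbon; here the chain itself changes, and with the diethylcarbamoyl group kept, this assay gives no change at the digits printed from compound 2 to compound 4 (within the scatter). The wider swaps, (diethylcarbamoyl)methyl in place of carboxy and in place of ethoxycarbonyl, give no change at the digits printed from compound 3 to compound 4 (within the scatter) and no change at the digits printed from compound 1 to compound 4 (within the scatter), so neither the extra chain carbon nor the end group has separated these four compounds in this assay. No supporting data bear on why the read-out stays level.

Still open, on these data alone, is whether a longer chain, or a primary amine or carboxylic acid at the end of the 2-(diethylcarbamoyl)ethyl-length chain, would move the read-out. Also open, as far as these compounds go, is whether hydroxy in place of the methoxy groups on the shared core would do so.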